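The compounds below may be only part of what the source reports. "The series", "measured", "known", "first", "only" and "open" are said of these compounds alone.

Compound 1 `CC1=C(C(=O)OCC(C)C)C(c2cccs2)NC(=O)N1`: 11%
Compound 2 `CC1=C(C(=O)OCC(C)C)C(c2cccs2)NC(=O)N1C`: 5%

Both compounds were tested in an assay on membranes from HeLa cells for displacement of a labelled ligand from adenosine receptor A3 (Homo sapiens), read by scintillation counting, with a stated time of 180 min, tested at 1 uM; on this read-out lower numbers stand for less inhibition and higher numbers for more inhibition at the one concentration tested (going by the name of the read-out). Compound 1 stands at 11%, and compound 2 at 5%. Among the measured compounds shown here, the one measured step, a number 6 percentage points lower from compound 1 to compound 2 (within the scatter), comes from methyl in place of hydrogen on an amide-type nitrogen in a ring and lies within the scatter, so the two numbers cannot be told apart.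

Compound 3 `CC1=C(C(=O)OC2CCC2)C(c2cccs2)NC(=O)N1` keeps the shared core of compound 1 and differs from it only at the oxygen next to a carbonyl group: cyclobutyl in place of isobutyl on an oxygen next to a carbonyl group. For the measured compounds named here, no measured step touches this part of the molecule; the step from compound 1 to compound 2 alters a different place. With nothing known for isobutoxy to cyclobutyloxy, no change beyond the scatter is expected, and the step is estimated as a number 1 percentage points lower from compound 1 to compound 3 (within the scatter). Compound 3 is therefore expected to give 10%, within 0% to 25%.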

Compound 3, a percentage reported as inhibition, at one concentration (the size of the read-out at that concentration, not a potency): 2%
Estimate against measurement, compound 3: 8 percentage points above; the range from low to high includes it.
By their numbers in this assay, from the lowest: compounds 3, 2 and 1 (each within the scatter of the next).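

Among the compounds shown here, this is the first measured change on the oxygen next to a carbonyl group: with cyclobutyl in place of isobutyl, both holding 4 carbon atoms, this assay shows a number 9 percentage points lower from compound 1 to compound 3 (within the scatter) for this swap. At this place, then, the one four-membered ring and the open branched chain cannot be told apart at the single concentration tested, and all three compounds lie within the scatter of one another. There is no measured information that could explain this result.

From the compounds shown here alone, it remains open whether a clearly different group on this oxygen, such as a benzyl group, a longer chain or a chain ending in an amine, would move the number beyond the scatter. Also open, going by these compounds, is how cyclobutyl behaves together with the methyl on the amide-type nitrogen of compound 2.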